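This account rests on a few compounds, and the source may have more. Where it says the series, first, only, none or still open, it means among the compounds named here.

The series brings together four compounds examined for cytotoxicity. Compound 1 `COC(=O)C1C(=O)C(C(=O)OC)[C@H](c2cccc([N+](=O)[O-])c2)N(Cc2ccc(OC)cc2)[C@@H]1c1cccc([N+](=O)[O-])c1` carries two nitrophenyl groups and two ester groups on its core. In an ADME assay on J774.1 cells (Mus musculus) for cytotoxicity, with a stated time of 48 h (on this read-out lower numbers stand for an effect already at smaller amounts and higher numbers for an effect only at larger amounts of compound), compound 1 reaches only the limit of the assay, > 100 uM; this is a limit and not a number, as the limit of > 100 uM in this assay, at which 1 of the 3 values shown sits, records. Compound 2 `C=CCN1[C@@H](c2ccccn2)CC(O)=C(C(=O)OC)[C@H]1c1ccccn1` bears two pyridyl groups and an allyl group on the ring nitrogen. In this assay compound 2 gives 35 uM. Compound 3 `C[C@@H]1CC2(C[C@H](C)N1)C(=O)N(Cc1ccc([N+](=O)[O-])cc1)C(=O)N2Cc1ccccc1`, built on a spirocyclic core, gives 42.4 uM in this assay, and this value lies within the scatter of that of compound 2, so the two cannot be told apart.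

Compound 4 `COC(=O)C1=C(O)C[C@H](c2ccccn2)N(Cc2ccc(C)cc2)[C@@H]1c1ccccn1` is not yet measured. It differs from compound 2 by 4-methylphenyl in place of vinyl on a saturated chain carbon bound to an amine nitrogen in a ring. Among the compounds with values here, no measured step of this kind exists among the three compounds above, so the expectation rests on compound 2 alone. The step of a 1.4-fold lower number from compound 2 to compound 4 (0.15 log units; within the scatter) is expected to stay close to the scatter, with a lower number somewhat more likely than a higher one. Compound 4 is therefore estimated at 25 uM, with a range from 8 uM to 80 uM.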

Compound 4, concentration for half-maximal effect: 34.9 uM
Estimate against measurement, compound 4: 1.4-fold (0.14 log units) below, within the range that was stated.
By their numbers in this assay, from the lowest: compounds 4, 2 and 3 (each within the scatter of the next). At a limit, above all of these: compound 1.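

In this assay, 4-methylphenyl in place of vinyl on a saturated chain carbon bound to an amine nitrogen in a ring gives a 1.0-fold lower number from compound 2 to compound 4 (0.00 log units; within the scatter). Within the data shown here, this is the first step between compounds that differ in one place, and it shows that a six-membered aromatic ring of carbon only can enter at this position, where the vinyl with its double bond leaves, without a difference that can be read in this assay. No information at hand bears on why the two compounds cannot be told apart.

From the compounds shown here alone, whether a group of another kind at this position, such as an amine, a carboxylic acid or a longer chain, would give a step beyond the scatter remains open. With a single step shown, the pyridyl groups and the ester on the shared core also remain unexamined.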